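Series notes: a benzyloxy variant awaiting measurement

The source may hold more compounds than are shown below. What is called first, only, known or untested is meant among the compounds shown, and "the series" means these compounds.

compound 1, `CC(C)CCOc1nc(C(C)(C)C)ccc1CNC(=O)C(C)c1ccc(NS(C)(=O)=O)c(F)c1`: 0.8 nM
compound 2, `CC1CCN(c2cc(C(C)(C)C)ccc2CNC(=O)C(C)c2ccc(NS(C)(=O)=O)c(F)c2)CC1`: 0.7 nM

In an assay on cells for antagonist activity at transient receptor potential cation channel subfamily V member 1 (Homo sapiens), read by FLIPR and calcium flux, with a stated time of 6 min (a lower number here means a stronger inhibitor, a higher number a weaker inhibitor), compound 1 gives 0.8 nM. Compound 2 gives 0.7 nM in this assay. Compound 2 holds the lower of the two numbers, but its gap to compound 1 lies within the scatter, so the two stand level. Compound 3, `CC(C(=O)NCc1ccc(C(C)(C)C)cc1OCc1ccc(F)cc1)c1ccc(NS(C)(=O)=O)c(F)c1`, differs from compound 2 by (4-fluorobenzyl)oxy in place of 4-methylpiperidin-1-yl on an aromatic carbon. Going by the values given here, no measured pair shows this change, so only an expectation is possible: the step from compound 2 to compound 3 is expected to be small, a 2.1-fold higher number from compound 2 to compound 3 (0.33 log units; beyond the scatter), toward a slightly higher number if any. Compound 3 is estimated at 1.5 nM in this assay, expected between 0.4 nM and 6 nM.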

Compound 3, inhibition constant: 3.8 nM
Estimate against measurement, compound 3: 2.5-fold (0.40 log units) below; measured number inside the range.
By their numbers in this assay, from the lowest: compounds 2 and 1 (each within the scatter of the next); then compound 3.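

In this assay, (4-fluorobenzyl)oxy in place of 4-methylpiperidin-1-yl on this aromatic carbon gives a 5.4-fold higher number from compound 2 to compound 3 (0.73 log units; beyond the scatter), a modest step. The position, ortho to a large group and meta to a tert-butyl group, therefore accepts a carbon-only aromatic ring in place of the non-aromatic ring, with compound 3 still at 3.8 nM in this assay. No measurement at hand bears on the reason for this step. As far as these compounds go, whether the step belongs to the fluorine, the benzyl ring or the oxygen remains open, as does how a morpholine or a plain butoxy chain would read at this carbon.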